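The source may report more compounds than this note shows. Statements on the series, on what has been measured and on what is new or still open speak of the compounds shown alone.

Measured so far:
compound 1 `CCC(CC)CNc1c(C(N)=O)cnc2ccc(-c3cccnc3)cc12` — 73 nM
compound 2 `CCC(CC)CNc1c(C(N)=O)cnc2ccc(-c3ccncc3)cc12` — 418 nM

In an assay on HT-29 cells for inhibition of Serine-protein kinase ATM (Homo sapiens), read by fluorescence, with a stated time of 1 h (on this read-out higher numbers stand for weaker inhibition and lower numbers for stronger inhibition), compound 2 gives the higher of the two numbers; the step of a 5.7-fold higher number from compound 1 to compound 2 (0.76 log units; beyond the scatter) is the only one recorded, and it concerns the same six-membered ring that is changed next. Compound 3 `CCC(CC)CNc1c(C(N)=O)cnc2ccc(-c3ccnnc3)cc12` carries a (pyridazin-4-yl in place of pyridin-4-yl on an aromatic carbon). Because the move a 5.7-fold higher number from compound 1 to compound 2 (0.76 log units; beyond the scatter) shows that this ring can shift the read-out well beyond the scatter, a change in this assay is expected again, toward a lower number. For compound 3 the estimate is 180 nM, within 50 nM to 600 nM, a step of a 2.3-fold lower number from compound 2 to compound 3 (0.37 log units; beyond the scatter).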

Compound 3, half-maximal inhibitory concentration: 908 nM
The estimate for compound 3 lay 5.0-fold (0.70 log units) below the measured number, outside the stated range (above it).
By their numbers in this assay, from the lowest: compound 1; then compound 2; then compound 3.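

Adding a second ring nitrogen at this position raises the number further in this assay (a 2.2-fold higher number from compound 2 to compound 3 (0.34 log units; beyond the scatter)), and the gap to the pyridin-3-yl ring is larger still (a 12-fold higher number from compound 1 to compound 3 (1.09 log units; beyond the scatter)). Among these three rings, then, both the number of ring nitrogens and their placement go with clear differences, and compound 1 keeps the lowest number. No measurement here gives a reason for these steps. Still open, on these data alone, is how a plain phenyl ring, with no ring nitrogen, or a pyrimidin-5-yl ring would read at this position.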